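This account rests on a few compounds, and the source may have more. Where it says the series, first, only, none or still open, it means among the compounds named here.

Compound 1 `COC(=O)c1cc(-c2cccc(NC(=O)c3ccc(/C=C/C(=O)c4ccccc4Br)cc3)c2)on1` is the point of departure. In an ADME assay on Vero cells (Chlorocebus sabaeus) for cytotoxicity, read by MTT assay, with a stated time of 72 h (a higher number here means that more compound is tolerated, a lower number that less compound is tolerated), compound 1 gives > 40 ug/mL, which is a limit of the assay rather than a number. Compound 2 `COC(=O)c1cc(-c2cccc(NC(=O)c3ccc(/C=C/C(=O)c4ccc(Cl)cc4)cc3)c2)on1` carries 4-chlorophenyl in place of 2-bromophenyl on a carbonyl carbon. In this assay compound 2 gives > 50 ug/mL, again a limit and not a number. The step that the two limits leave unreadable from compound 1 to compound 2 therefore cannot be read in size, since both ends rest at limits, namely the limit of > 40 ug/mL in this assay, at which 1 of the 3 values shown sits, and (the limit of > 50 ug/mL in this assay, at which 1 of the 3 values shown sits). Compound 3 `COC(=O)c1cc(-c2cccc(NC(=O)/C=C/c3ccc(Cl)cc3)c2)on1` has no result in this assay: "not determined" (no result reported). Compound 4 `COC(=O)c1cc(-c2cccc(NC(=O)c3ccc(/C=C/C(=O)c4ccc(CC(C)C)cc4)cc3)c2)on1` differs from compound 1 by 4-isobutylphenyl in place of 2-bromophenyl on a carbonyl carbon. Among the compounds with values here, no measured step has a readable size that bears on this change; the one comparison available, from compound 1 to compound 2, shows only that both ends were tolerated up to their limits. Compound 4 is thus expected to sit near compound 1, with the step that the limit leaves unreadable from compound 1 to compound 4 expected to stay within the scatter. The estimate for compound 4 in this assay is 50 ug/mL, spanning 25 ug/mL to 100 ug/mL, and most likely again reported as a limit.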

Compound 4, half-maximal cytotoxic concentration: > 10 ug/mL
Compound 4: only a limit was reported; the forecaster's own chance of this, stated with the estimate: 75%; the middle value is on the limit's open side.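

In this assay compound 4 gives > 10 ug/mL, which is a limit of the assay and not a number. The steps to compound 4 from compound 1 and from compound 2 cannot be read in size. Where compound 1, compound 2 and compound 4 actually sit in this assay stays open, and with it whether these changes on the aromatic ring shift tolerance at all.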